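Notes on the shared core: compound 2 to compound 3

The compounds below may be only part of what the source reports. "The series", "measured", "known", "first", "only" and "open" are said of these compounds alone.

Two compounds of the series have numbers in an assay for antagonist activity at proteinase-activated receptor 4 (Homo sapiens), read by flow cytometry, with a stated time of 20 min; on this read-out higher numbers stand for weaker inhibition and lower numbers for stronger inhibition. Compound 1 `COc1nn2cc(-c3cccc(F)c3)nc2s1` gives 675 nM; 676 nM (2 entries), and the several entries of compound 1 in this assay, 675 nM; 676 nM (2 entries) shows its repeat entries in close agreement. Within the data shown here, compound 2 `CN(C)c1nn2cc(-c3c(F)cccc3F)nc2s1` carries dimethylamino on the shared core; in this assay compound 2 gives 3400 nM, the only number it has, with one further entry that yields no single number. Compound 2 is weaker than compound 1 on the numbers shown, but the two structures differ in more than one place, so no single step is drawn between them. Compound 3 `CNc1nn2cc(-c3c(F)cccc3F)nc2s1` is the next member to be measured. It differs from compound 2 by hydrogen in place of methyl on a nitrogen on an aromatic ring. Among the measured compounds shown here, no measured step of this kind exists, so the expected size is small, in either direction, most likely nothing beyond the scatter and at best a modest gain. Compound 3 is therefore expected to give 2500 nM, within 800 nM to 8000 nM. That estimate corresponds to the expected step of a 1.4-fold lower number from compound 2 to compound 3 (0.13 log units; within the scatter).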

Compound 3, half-maximal inhibitory concentration: > 10000 nM
Compound 3: only a limit was reported; the forecaster's own chance of this, stated with the estimate: 10%; middle value at least 4.0-fold (0.60 log units) away from the limit.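

Taking one methyl off the dimethylamino group of compound 2 to leave methylamino gives an at least 2.9-fold higher number from compound 2 to compound 3 (0.46 log units; beyond the scatter) in this assay, the only measured step in the series on this nitrogen on an aromatic ring, and it shows that inhibition at this position responds to a change of a single methyl, with the second methyl going with the stronger inhibition in this pair. For compound 3, the reported > 10000 nM is a limit of the assay and not a number. The true size of the loss stays unknown and the step gives only its smallest possible size, because compound 3 stands at that limit: the limit of > 10000 nM in this assay, at which 1 of the 3 values shown sits.

One pair cannot tell whether a second methyl is specifically needed on this nitrogen or whether a longer chain such as ethyl, or a cyclic amine such as pyrrolidine, would hold or improve on the inhibition of compound 2. Among these compounds, it also remains open how the unsubstituted amine would read on the same core, and whether the same step would appear with the aryl group of compound 1 in place of the one carried by compound 2 and compound 3.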